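A few compounds are considered here, and "the series" means these few. Any claim that something is new, unique, unknown or untested is made for them only; others in the source may bear on it.

In a functional assay on MT4 cells (Homo sapiens) (a lower number here means that less compound is tolerated, a higher number that more compound is tolerated), compound 1 `Cc1cn([C@@H]2O[C@@H]3COC4(O)CS(=O)(=O)O[C@@]34[C@H]2O)c(=O)[nH]c1=O` gives 100000 nM, and compound 3 `Cc1cn([C@@H]2O[C@@H]3COC4(O)CS(=O)(=O)O[C@@]34[C@H]2O[Si](C)(C)C(C)(C)C)c(=O)[nH]c1=O` gives 100000 nM. Compound 2 `COC(=O)CC(=O)NC1=CS(=O)(=O)O[C@@]12[C@@H](CO[Si](C)(C)C(C)(C)C)O[C@@H](n1cc(C)c(=O)n(C)c1=O)[C@@H]2O[Si](C)(C)C(C)(C)C` gives 11900 nM, the lowest of the three numbers and beyond the usual scatter from the other two. Compound 2 is therefore the natural reference for compound 4 `Cc1cn([C@@H]2O[C@H](CO[Si](C)(C)C(C)(C)C)[C@@]3(OS(=O)(=O)C=C3NCC(=O)C(N)=O)[C@H]2O[Si](C)(C)C(C)(C)C)c(=O)n(C)c1=O`, which has not yet been measured. The two differ in one place: (carbamoylcarbonyl)methyl in place of ((methoxycarbonyl)methyl)carbonyl on an amine nitrogen. In plain terms, a (carbamoylcarbonyl)methyl group takes the place of a ((methoxycarbonyl)methyl)carbonyl group on an amine nitrogen, and the rest of the structure stays the same.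

Within the data shown here, only one measured step changes a single place, no change at the digits printed from compound 1 to compound 3 (within the scatter). That step offers limited guidance, as it happens at an oxygen on a saturated carbon, not on the amine nitrogen. Among the measured compounds shown here, neither compound 1 nor compound 3 carries a group on such a nitrogen, so no measured step shows what a swap at this place does. With no evidence for a direction, the expected change is a 1.2-fold higher number from compound 2 to compound 4 (0.07 log units; within the scatter), which means no clear shift beyond the scatter. For compound 4 the estimated value is 14000 nM, with an expected range from 4500 nM to 60000 nM.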

Compound 4, half-maximal cytotoxic concentration: 9590 nM
Compound 4: middle estimate off by 1.5-fold (0.16 log units), on the high side, within the range that was stated.
By their numbers in this assay, from the lowest: compounds 4 and 2 (each within the scatter of the next); then compounds 1 and 3 (each within the scatter of the next).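

Among the compounds shown, this is the only step on the amine nitrogen whose other neighbour is the double-bonded ring carbon. In this assay, putting (carbamoylcarbonyl)methyl in place of ((methoxycarbonyl)methyl)carbonyl gives a 1.2-fold lower number from compound 2 to compound 4 (0.09 log units; within the scatter) and so separates the two compounds by no clear margin. The entering group has 1 hydrogen-bond donor and the leaving group has 0, yet for this one pair that difference, together with the different arrangement of atoms in the chain, comes with no shift in the concentration tolerated by the cells. Nothing measured alongside these numbers accounts for this outcome.

The compounds shown leave open whether this holds for other groups on the same nitrogen: a plain amine, a carboxylic acid or a longer chain could each give a different number. A single pair also cannot say whether any group at this place would move the half-maximal cytotoxic concentration beyond the scatter, or whether the same swap would give the same result on the core of compound 1.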